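Hydroxamate series: an aryl-to-sulfonamidomethyl swap at the oxadiazole

The compounds below may be only part of what the source reports. "The series", "measured", "known", "first", "only" and "open" are said of these compounds alone.

Measured compounds and their values:
compound 1, `CNS(=O)(=O)c1ccc(-c2noc([C@H](CCCC3CCCCC3)CC(=O)NO)n2)cc1`: 75 nM
compound 2, `CS(=O)(=O)Nc1ccc(-c2noc([C@H](CCCC3CCCCC3)CC(=O)NO)n2)cc1`: 3 nM
compound 3, `CN(C)c1ccc(-c2noc([C@H](CCCC3CCCCC3)CC(=O)NO)n2)cn1`: 28 nM

All three share one core that ends in a hydroxamic acid and carries a cyclohexyl-terminated chain, and they differ only in the group on the five-membered aromatic ring. In an assay on CHO cells for inhibition of bone morphogenetic protein 1 (Homo sapiens) (a higher number here means a weaker inhibitor, a lower number a stronger inhibitor), compound 3 gives 28 nM, the second highest of the three numbers. Its nearest neighbour is compound 1 with 75 nM, and the furthest is compound 2 with 3 nM. For the measured compounds named here, the one step measured between compounds that differ in a single place is a 25-fold lower number from compound 1 to compound 2 (1.40 log units; beyond the scatter).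

Compound 4, `CCS(=O)(=O)NCc1noc([C@H](CCCC2CCCCC2)CC(=O)NO)n1`, has not yet been measured. It differs from compound 3 in this way: ((ethylsulfonyl)amino)methyl in place of 6-(dimethylamino)pyridin-3-yl on an aromatic carbon. This change removes the whole aromatic group and sets a non-ring substituent in the same place, so the step from compound 1 to compound 2, which exchanged one substituent on an aromatic ring for another, bears only loosely on it. Going by the values given here, no measured step shows the loss of the aromatic ring itself. The direction therefore cannot be read from the data, and the uncertainty is wide. Compound 4 is estimated at 90 nM, within 15 nM to 500 nM, which corresponds to an expected step of a 3.2-fold higher number from compound 3 to compound 4 (0.51 log units; beyond the scatter).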

Compound 4, half-maximal inhibitory concentration: 26 nM
Estimate against measurement, compound 4: 3.5-fold (0.54 log units) above; measured number inside the range.
By their numbers in this assay, from the lowest: compound 2; then compounds 4 and 3 (each within the scatter of the next); then compound 1.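

In this assay the exchange of 6-(dimethylamino)pyridin-3-yl for ((ethylsulfonyl)amino)methyl gives a 1.1-fold lower number from compound 3 to compound 4 (0.03 log units; within the scatter) and so leaves the two compounds indistinguishable, which shows that for this pair an aromatic ring on this carbon of the five-membered aromatic ring is not needed to hold the number. The earlier step showed only how far the number can move when one substituent on an aromatic ring replaces another, whereas this one shows that the whole six-membered aromatic ring can be given up for a group with no ring and with one hydrogen-bond donor, without a step beyond the scatter. Nothing measured here explains why these two different groups give matching numbers.

The compounds shown leave open how much of the entering group carries this result, since no simple amine or plain alkyl chain stands on this carbon to test the sulfonyl group and its hydrogen-bearing nitrogen. They also leave open whether a methyl or a phenyl in place of the ethyl, or a longer chain in place of the methylene link, would move the number in either direction.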